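The source may report more compounds than this note shows. Statements on the series, on what has been measured and on what is new or still open speak of the compounds shown alone.

Measured compounds in a functional assay on NCI-H1581 cells (Homo sapiens) for inhibition, read by MTT assay, with a stated time of 48 h, tested at 10 uM; on this read-out lower numbers stand for less inhibition and higher numbers for more inhibition at the one concentration tested (going by the name of the read-out):
Compound 1, `COc1cc(NC(=O)Nc2cc(Nc3ccc(OC)c(C)c3)ncn2)cc(OC)c1`, gives 19.7%.
Compound 2, `COc1cc(Br)ccc1Nc1cc(NC(=O)Nc2c(Cl)cccc2Cl)ncn1`, gives 47.3%.
Compound 3, `COc1ccc(C(F)(F)F)cc1Nc1cc(NC(=O)Nc2c(Cl)cccc2Cl)ncn1`, gives 69.1%.

Among these three numbers compound 1 stands lowest. Compound 2 is nearest to it, with a number higher by a margin beyond the scatter, and compound 3 lies furthest, higher still and also beyond the scatter. Going by the values given here, compound 2 and compound 3 each differ from compound 1 in more than one place, so no pair of measured compounds is separated by a single change, and the two higher numbers cannot be traced to any one part of the structure.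

The unmeasured compound 4, `COc1cc(NC(=O)Nc2cc(Nc3ccc(C(C)(C)C)cc3)ncn2)cc(OC)c1`, differs from compound 1 in one place only: 4-(tert-butyl)phenyl in place of 4-methoxy-3-methylphenyl on a nitrogen on an aromatic ring. Among the compounds with values here, no measured pair shows this change, so nothing in the data fixes its size or direction. Given that compound 1 sits at 19.7% and that the only higher numbers belong to compounds altered elsewhere as well, the step of a number 6.3 percentage points higher from compound 1 to compound 4 (within the scatter) is expected to be small, upward if anything, and not clearly beyond the scatter. Compound 4 is therefore estimated at 26%, with a range from 8% to 46%.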

Compound 4, a percentage reported as inhibition, at one concentration (the size of the read-out at that concentration, not a potency): 38.7%
Compound 4: the middle estimate sits 12.7 percentage points below what was measured; measured number inside the range.
By their numbers in this assay, from the lowest: compound 1; then compounds 4 and 2 (each within the scatter of the next); then compound 3.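

In this assay, going by these compounds alone, the exchange of 4-methoxy-3-methylphenyl for 4-(tert-butyl)phenyl on a nitrogen on an aromatic ring gives a number 19 percentage points higher from compound 1 to compound 4 (beyond the scatter) and supplies the first single-change comparison in this set. It shows that, on the core of compound 1, the read-out responds to the group at this position. The earlier compounds shown here could not establish this point. Each of them differed from compound 1 in more than one place. The change replaces a group holding one oxygen and one hydrogen-bond acceptor with an all-carbon group of 10 heavy atoms, but nothing measured here explains why the number rose.

The compounds shown leave open whether the step follows from the loss of the methoxy group, the loss of the methyl group or the arrival of the tert-butyl group, since all three changes occur together. They also leave open how this position would respond to an isopropyl group, a morpholine or a carboxylic acid, and whether 4-(tert-butyl)phenyl would give a similar step on a different remainder of the molecule.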